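Methylamino for methoxy on the carbonyl: second instance

The source may report more compounds than this note shows. Statements on the series, on what has been measured and on what is new or still open speak of the compounds shown alone.

Values below come from a functional assay for agonist activity at follicle-stimulating hormone receptor (Homo sapiens), read by a luciferase reporter; on this read-out lower numbers stand for an effect already at smaller amounts and higher numbers for an effect only at larger amounts of compound.

compound 1, `CCCCCCN1C(=O)[C@H](Cc2ccc(-c3cccc(CN(CCCC)C(=O)OC)c3)cc2)N(C)C(=O)[C@@H]1C`: 8.9 nM
compound 2, `CCCCCCN1C(=O)[C@H](Cc2ccc(-c3cccc(CN(CCCC)C(=O)NC)c3)cc2)N(C)C(=O)[C@@H]1C`: 7.2 nM
compound 3, `CCCCCCCCN1C(=O)[C@H](Cc2ccc(-c3cccc(CN(COC)C(=O)OC)c3)cc2)N(C)C(=O)[C@@H]1C`: 1.8 nM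

Compound 4, `CCCCCCCCN1C(=O)[C@H](Cc2ccc(-c3cccc(CN(COC)C(=O)NC)c3)cc2)N(C)C(=O)[C@@H]1C`, has not yet been measured in this assay.

From compound 1 to compound 2 the change is methylamino in place of methoxy on a carbonyl carbon. It gave a 1.2-fold lower number from compound 1 to compound 2 (0.09 log units; within the scatter), so the two values are not separated by this assay. Compound 3 carries a different core; how its core differs from that of compound 1 is not broken down here. In this assay compound 3 gives 1.8 nM, the lowest number of the three measured compounds, beyond the scatter from both compound 1 and compound 2.

Compound 4 differs from compound 3 by methylamino in place of methoxy on a carbonyl carbon. This is the same change, at the same place, as that made from compound 1 to compound 2; among the compounds shown it occurs twice. Among the measured compounds shown here, only one measured instance exists, and it sits on a different core, so its transfer to compound 3 is not secured by any other pair.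

The step expected in this assay is a 1.2-fold lower number from compound 3 to compound 4 (0.08 log units; within the scatter), set beside the measured step, because a 1.2-fold lower number from compound 1 to compound 2 (0.09 log units; within the scatter) stayed within the scatter and nothing shown argues for a larger effect on the core of compound 3. Compound 4 is estimated to give about 1.5 nM. For compound 4 the expected range runs from 0.7 nM to 3.2 nM.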

Compound 4, half-maximal effective concentration: 3.6 nM
For compound 4 the middle estimate is 2.4-fold (0.38 log units) below the measured one, outside the stated range (above it).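

In this assay the new pair gives a 2.0-fold higher number from compound 3 to compound 4 (0.30 log units; within the scatter), so methylamino in place of methoxy on a carbonyl carbon does not separate the two compounds on this core, just as it did not on the core of compound 1. Set side by side, the two instances of the change cannot be told apart in this assay: the same change on two cores in this assay, a 1.2-fold lower number (0.09 log units; within the scatter) from compound 1 to compound 2 and a 2.0-fold higher number (0.30 log units; within the scatter) from compound 3 to compound 4, 2.5-fold (0.39 log units) apart, within the scatter of two such steps This supports carrying the change between these two cores without expecting a step beyond the scatter, but it does not show that the change is without effect in general, since the series offers only two pairs and any true difference smaller than the scatter would go unseen.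

Still open, from the compounds shown here alone, is whether other groups on the same carbonyl carbon, such as ethylamino, dimethylamino or a plain methyl, would match methylamino or methoxy. Also open, going by these compounds, is whether the change would stay within the scatter on a third core, for example one with a benzyl group in place of the butyl or methoxymethyl group on the amide-type nitrogen.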